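This account rests on a few compounds, and the source may have more. Where it says the series, first, only, none or still open, it means among the compounds named here.

Measured so far:
compound 1 `OCc1cc(O)c(O)c(Br)c1` — "not determined" (no result reported)
compound 2 `O=Cc1cc(O)c(O)c(Br)c1Br` — "not determined" (no result reported)
compound 3 `OCc1cc(Br)c(O)c(O)c1Br` — 21400 nM

In a functional assay on HCT-116 cells (Homo sapiens) for cytotoxicity, read by MTT assay, with a stated time of 96 h (a lower number here means a stronger inhibitor, a higher number a weaker inhibitor), compound 3 gives 21400 nM. This is the only number shown; for compound 1 and compound 2 no result was reported, so compound 3 cannot be set against anything else in this assay. Compound 4 `COCc1cc(Br)c(O)c(O)c1Br` differs from compound 3 by methyl in place of hydrogen on an oxygen on a saturated carbon, a change of one carbon and no change in donors or acceptors. For the measured compounds named here, there is no step between measured compounds to show how large such a change can be, so the expectation rests on the size of the change alone. The step of a 1.0-fold higher number from compound 3 to compound 4 (0.01 log units; within the scatter) is expected to be small, within the usual scatter, in either direction. Compound 4 is estimated at 22000 nM, in a range from 7000 nM to 70000 nM.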

Compound 4, half-maximal inhibitory concentration: 3480 nM
Estimate against measurement, compound 4: 6.3-fold (0.80 log units) above; the whole stated range lies above it.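

In this assay, turning hydroxymethyl into methoxymethyl gives a 6.1-fold lower number from compound 3 to compound 4 (0.79 log units; beyond the scatter), so this position responds to a single added carbon, and the hydrogen on that oxygen is not needed for activity in these cells. For the compounds shown here, this is the first readable step, and it lies beyond the scatter. No measurement at hand explains why the number falls. Still open, going by these compounds, is whether a longer chain on that oxygen, such as ethoxymethyl, would lower the number further. An amine or a carboxylic acid at this position is also untested by the compounds shown.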